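Replacing 3-chlorophenyl with 2-fluorophenyl

The source may hold more compounds than are shown below. What is called first, only, known or untested is meant among the compounds shown, and "the series" means these compounds.

In an ADME assay on L132 cells (Homo sapiens) for cytotoxicity, read by MTT assay, with a stated time of 48 h (a higher number here means a weaker inhibitor, a lower number a stronger inhibitor), compound 1 `C/C(=C\CC/C(C)=C/CC[C@@H]1[C@@]2(C)CCC(=O)C(C)(C)[C@H]2CC[C@@]1(C)O)CC/C=C(\C)C(=O)OCc1cn(-c2ccc([N+](=O)[O-])cc2)nn1` gives > 150000 nM, which is a limit of the assay and not a number. Compound 2 `C/C(=C\CC/C(C)=C/CC[C@@H]1[C@@]2(C)CCC(=O)C(C)(C)[C@H]2CC[C@@]1(C)O)CC/C=C(\C)C(=O)OCc1cn(-c2ccc(Br)cc2)nn1` gives > 150000 nM, again a limit and not a number. For the measured compounds named here, compound 3 `C/C(=C\CC/C(C)=C/CC[C@@H]1[C@@]2(C)CCC(=O)C(C)(C)[C@H]2CC[C@@]1(C)O)CC/C=C(\C)C(=O)OCc1cn(-c2cccc(Cl)c2)nn1` gives 94200 nM, the only actual number among the three.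

Compound 4 `C/C(=C\CC/C(C)=C/CC[C@@H]1[C@@]2(C)CCC(=O)C(C)(C)[C@H]2CC[C@@]1(C)O)CC/C=C(\C)C(=O)OCc1cn(-c2ccccc2F)nn1` has not yet been measured in this assay. It carries 2-fluorophenyl in place of 3-chlorophenyl on an aromatic nitrogen.

Two measured steps change the group at this same place: an at least 1.5-fold lower number from compound 1 to compound 3 (0.20 log units; that floor lies within the scatter) and an at least 1.5-fold lower number from compound 2 to compound 3 (0.20 log units; that floor lies within the scatter). Going by these compounds, each can be read only as a floor because of the limit of > 150000 nM in this assay, at which 2 of the 3 values shown sit, so their true sizes remain unknown. Going by the values given here, no measured compound carries 2-fluorophenyl, which makes this a cautious extrapolation.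

Compound 3 at 94200 nM is the natural starting point, and the floors of an at least 1.5-fold lower number from compound 1 to compound 3 (0.20 log units; that floor lies within the scatter) and an at least 1.5-fold lower number from compound 2 to compound 3 (0.20 log units; that floor lies within the scatter) give no reason to expect a large move. The expected change is a slightly higher number, a 1.3-fold higher number from compound 3 to compound 4 (0.11 log units; within the scatter), with no step beyond the scatter anticipated. For compound 4 the estimate is 120000 nM, with an expected range from 70000 nM to 200000 nM.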

Compound 4, half-maximal inhibitory concentration: > 150000 nM
Compound 4: no number, only a limit; the forecaster's own chance of this, stated with the estimate: 50%; middle value at least 1.2-fold (0.09 log units) from the limit.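

In this assay, compound 4 gives > 150000 nM, which is a limit of the assay and not a number. For the compounds shown here, putting 2-fluorophenyl in place of 3-chlorophenyl on the aromatic nitrogen gives an at least 1.5-fold higher number from compound 3 to compound 4 (0.20 log units; that floor lies within the scatter), so this change shows no step that can be told apart from the scatter, and compound 3 remains the only compound here with an actual number. The steps from compound 1 and from compound 2 to compound 4 cannot be read, and the series now says little about this position for one plain reason: the limit of > 150000 nM in this assay, at which 3 of the 4 values shown sit.

Going by these compounds, compound 3 and compound 4 differ in both the halogen and its place on the phenyl ring, so the two effects cannot be separated, and it remains open which of them, if either, matters in this assay. Also open, on these data alone, is whether a phenyl ring carrying an amine or a carboxylic acid, or a plain benzyl group on the same ring nitrogen, would give a real number rather than a limit.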